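Ethylamino in Place of Methylamino on Two Cores

The compounds below may be only part of what the source reports. "The series", "measured", "known", "first", "only" and "open" are said of these compounds alone.

Compound 1 `CNCC(=O)Nc1cc(OC)ccc1C(=O)c1ccc2c(c1)C=CC(C)(C)O2` gives 1010 nM in a functional assay on HCT-8 cells (Homo sapiens) for antiproliferative activity, read by MTT assay, with a stated time of 48 h; on this read-out higher numbers stand for weaker inhibition and lower numbers for stronger inhibition.
Compound 2 `CCNCC(=O)Nc1cc(OC)ccc1C(=O)c1ccc2c(c1)C=CC(C)(C)O2` gives 3990 nM in this assay.
Compound 3 `CNCC(=O)Nc1cc(OC)ccc1C(=O)c1cc(OC)c(OC)c(OC)c1` gives 780 nM in this assay.

Compound 4 `CCNCC(=O)Nc1cc(OC)ccc1C(=O)c1cc(OC)c(OC)c(OC)c1` has not yet been measured in this assay. It differs from compound 3 by methyl in place of hydrogen on a saturated chain carbon bound to an amine nitrogen, the same change that separates compound 2 from compound 1, namely (methyl in place of hydrogen on a saturated chain carbon bound to an amine nitrogen). The difference between the two cores is not broken down here. That change, made once so far, gave a 4.0-fold higher number from compound 1 to compound 2 (0.60 log units; beyond the scatter). Among the compounds with values here, on the core of compound 3 one measured point exists, and the step from compound 1 to compound 2 is the only guide. A similar step is therefore expected for compound 4, a 3.8-fold higher number from compound 3 to compound 4 (0.59 log units; beyond the scatter), resting on a 4.0-fold higher number from compound 1 to compound 2 (0.60 log units; beyond the scatter). Compound 4 is estimated at 3000 nM, between 1200 nM and 8000 nM.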

Compound 4, half-maximal inhibitory concentration: 1560 nM
Compound 4: middle estimate off by 1.9-fold (0.28 log units), on the high side; the range from low to high includes it.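

In this assay the change from methylamino to ethylamino, carried to the core of compound 3, gives a 2.0-fold higher number from compound 3 to compound 4 (0.30 log units; within the scatter) on that core. Set beside the earlier step, the two cannot be told apart: the same change on two cores in this assay, a 4.0-fold higher number (0.60 log units; beyond the scatter) from compound 1 to compound 2 and a 2.0-fold higher number (0.30 log units; within the scatter) from compound 3 to compound 4, 2.0-fold (0.30 log units) apart, within the scatter of two such steps.
Within the data shown here, this shows that the two cores give steps that agree within what two such steps can resolve, but it does not show that the step has a fixed size, since the step on the core of compound 3 does not itself stand clear of the scatter and each core offers only one pair.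

The compounds shown leave open how a longer chain, such as propylamino, would behave in this place. The same holds for a dimethylamino group or a cyclic amine such as pyrrolidine, on either core.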